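Changing the Ring Group in Compound 4

The source may report more compounds than this note shows. Statements on the series, on what has been measured and on what is new or still open speak of the compounds shown alone.

Compound 1, `CC(C)[C@H](NC(=O)COc1cccc2ccccc12)C(=O)N[C@@H](CC(=O)O)C(=O)CSc1ncc[nH]1`, is the starting point. In a functional assay on Jurkat cells (Homo sapiens) for inhibition (a higher number here means a weaker inhibitor, a lower number a stronger inhibitor), compound 1 gives > 200000 nM, which is a limit of the assay rather than a measured number. Compound 2, `CC(C)[C@H](NC(=O)COc1cccc2ccccc12)C(=O)N[C@@H](CC(=O)O)C(=O)CSc1nc(-c2ccccc2)cs1`, also gives only a limit, > 200000 nM. Compound 3, `CC(C)[C@H](NC(=O)COc1cccc2ccccc12)C(=O)N[C@@H](CC(=O)O)C(=O)COc1ccccn1`, likewise gives only a limit, > 200000 nM. Among the measured compounds shown here, all three values sit at the limit of > 200000 nM in this assay, at which 3 of the 3 values shown sit, so the steps a step that the two limits leave unreadable from compound 1 to compound 2, a step that the two limits leave unreadable from compound 1 to compound 3 and a step that the two limits leave unreadable from compound 2 to compound 3 cannot be read in size or direction; they show only that exchanging the group on the saturated chain carbon bound to the carbonyl carbon did not bring any compound below the limit.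

Compound 4, `CC(C)[C@H](NC(=O)COc1cccc2ccccc12)C(=O)N[C@@H](CC(=O)O)C(=O)COc1ccncn1`, differs from compound 1 at that same place: (pyrimidin-4-yl)oxy in place of (1H-imidazol-2-yl)sulfanyl on a saturated chain carbon bound to a carbonyl carbon. Every measured change at this position has left the value at the limit, so this one is expected to do the same. Compound 4 is therefore expected to give 250000 nM, with a range of 100000 nM to 1000000 nM, meaning an expected step that the limit leaves unreadable from compound 1 to compound 4 that most likely again appears only as a limit.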

Compound 4, half-maximal inhibitory concentration: > 200000 nM
Compound 4 ended at the assay's limit; the forecaster's own chance of this, stated with the estimate: 85%; the middle value lies beyond the limit too.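

In this assay compound 4 gives > 200000 nM, which is a limit and not a number. The steps to compound 4 from compound 1, compound 2 and compound 3 therefore cannot be read in size or direction. The compounds shown leave open which group at this place, if any, would give a measurable value.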